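The source may hold more compounds than are shown below. What is called first, only, known or untested is meant among the compounds shown, and "the series" means these compounds.

Measured compounds in the series:
compound 1 `CCOC1=C(C(=O)c2ccccc2)C(c2ccc(Br)cc2)N(CCCn2ccnc2)C1=O` with 31700 nM
compound 2 `CCOc1ccc(NC2=C(C(=O)c3ccccc3)C(c3ccc(Br)cc3)N(CCCn3ccnc3)C2=O)cc1` with 30900 nM

Both numbers come from a functional assay on SAOS-2 cells (Homo sapiens) for antiproliferative activity, read by MTT assay, with a stated time of 72 h; on this read-out lower numbers stand for stronger inhibition and higher numbers for weaker inhibition. Among the measured compounds shown here, compound 2 has the lowest number of the two measured in this assay, but the only neighbour is compound 1, and the step of a 1.0-fold lower number from compound 1 to compound 2 (0.01 log units; within the scatter) is within the scatter, so no order between compound 1 and compound 2 can be claimed.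

Compound 3 `O=C(C1=C(NCc2ccccc2)C(=O)N(CCCn2ccnc2)C1c1ccc(Br)cc1)c1ccccc1` has not yet been measured in this assay. It differs from compound 2 by benzyl in place of 4-ethoxyphenyl on an amine nitrogen. For the measured compounds named here, the one measured step that touches this position, a 1.0-fold lower number from compound 1 to compound 2 (0.01 log units; within the scatter), replaced ethoxy with (4-ethoxyphenyl)amino on the double-bonded ring carbon and left the number unchanged within the scatter. Going by the values given here, no measured step tests a benzyl group on the amine nitrogen, so the present change carries little direct precedent beyond that single step at the same position, which showed no movement.

On that basis compound 3 is expected to stay close to compound 2, with an expected step of a 1.0-fold lower number from compound 2 to compound 3 (0.01 log units; within the scatter) that does not go beyond the scatter. The estimate for compound 3 in this assay is 30000 nM, with a range from 12000 nM to 75000 nM.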

Compound 3, half-maximal inhibitory concentration: 31600 nM
Compound 3: the middle estimate sits 1.1-fold (0.02 log units) below what was measured; the measured number falls inside the stated range.
By their numbers in this assay, from the lowest: compounds 2, 3 and 1 (each within the scatter of the next).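

In this assay, among the compounds shown here, benzyl in place of 4-ethoxyphenyl on the amine nitrogen gives a 1.0-fold higher number from compound 2 to compound 3 (0.01 log units; within the scatter); this is the first measured change on that nitrogen itself, whereas the earlier step replaced the whole group on the double-bonded ring carbon. Benzylamino in place of ethoxy on the double-bonded ring carbon gives a 1.0-fold lower number from compound 1 to compound 3 (0.00 log units; within the scatter), so ethoxy, (4-ethoxyphenyl)amino and benzylamino all lie within the scatter of one another and no order among them can be drawn, even though the exchange on the nitrogen removes the ring-bound ethoxy oxygen and brings in a group of 7 heavy atoms in place of 9. Nothing at hand offers an explanation for this flat read-out at the position.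

From the compounds shown here alone, whether a different kind of group on the amine nitrogen, such as a carboxylic acid or a longer alkyl chain, would move the number beyond the scatter remains open. Going by these compounds, all three compounds also share the rest of the core, so it remains open whether this flatness would persist with, for example, a chlorine in place of the bromine on the aryl ring.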